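This account rests on a few compounds, and the source may have more. Where it says the series, first, only, none or still open, it means among the compounds named here.

Measured in a functional assay on HeLa cells (Homo sapiens) for cytotoxicity; on this read-out lower numbers stand for stronger inhibition of growth and higher numbers for weaker inhibition of growth:
- compound 1 `COc1ccc(NS(=O)(=O)c2c(F)c(F)c(F)c(F)c2Br)cc1`: 160 nM
- compound 2 `COc1ccc(NS(=O)(=O)c2cc(F)c(F)c(F)c2F)cc1`: 370 nM
- compound 3 `COc1ccc(NS(=O)(=O)c2c(F)cc(F)c(F)c2F)cc1`: 5800 nM

Compound 2 stands second highest of the three numbers in this assay. It lies close to compound 1 and far from compound 3, whose 5800 nM is the highest number of the set.

The next compound to be tested is compound 4 `COc1ccc(NS(=O)(=O)c2cc(F)c(Cl)c(F)c2F)cc1`, which carries chloro in place of fluoro on an aromatic carbon, para to a large group: chloro in place of fluoro on an aromatic carbon.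

Among the compounds with values here, only one measured step bears on this change: a 2.3-fold higher number from compound 1 to compound 2 (0.36 log units; beyond the scatter). It is a modest step, and it exchanges bromo and hydrogen on a different aromatic carbon, so it offers only weak guidance. Within the data shown here, no step from fluoro to chloro has been measured. The gap between compound 2 and compound 3 comes with a different arrangement of the fluoro groups and says nothing direct about this exchange, though it leaves open a larger shift in either direction.

A small move toward a lower number is therefore expected, no larger than the measured modest step. The expected step is a 1.3-fold lower number from compound 2 to compound 4 (0.12 log units; within the scatter). For compound 4 the estimated value is 280 nM, with an expected range from 100 nM to 800 nM.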

Compound 4, concentration for 50% growth inhibition: 21000 nM
For compound 4 the middle estimate is 75-fold (1.88 log units) below the measured one; the whole stated range lies below it.
By their numbers in this assay, from the lowest: compound 1; then compound 2; then compound 3; then compound 4.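

In this assay, the aromatic carbon para to a large group and ortho to two fluoro groups proves highly sensitive to substitution: chloro in place of fluoro gives a 57-fold higher number from compound 2 to compound 4 (1.75 log units; beyond the scatter). This large step far exceeds the modest 2.3-fold higher number from compound 1 to compound 2 (0.36 log units; beyond the scatter), which involves a different aromatic carbon, so the earlier step gave no sign of how little tolerance this position would show. A single exchange of one halogen atom, with no change in ring, hydrogen-bond donor or acceptor counts, or net charge, is enough to take compound 4 to 21000 nM, and nothing available accounts for the size of this loss.

Going by these compounds, it remains open whether the loss is particular to chloro or extends to other replacements of fluoro at this position, such as a methyl group, a methoxy group or an amine, and whether any of these would keep the number near that of compound 2. Also open, on these data alone, is whether chloro in place of fluoro on the other fluorinated aromatic carbons of compound 2 would produce a step of similar size.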